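The source may hold more compounds than are shown below. What is called first, only, known or untested is meant among the compounds shown, and "the series" means these compounds.

Compounds 1, 2 and 3 share one core and differ only in the group carried on the saturated chain carbon bound to the aromatic nitrogen. In an assay on isolated protein (Oryctolagus cuniculus) with Thromboxane-A synthase (Homo sapiens) as the target, tested at 1 uM (a higher number here means more inhibition at the concentration tested (going by the name of the read-out), a lower number less inhibition), compound 1 `CCCCCCCCn1nc(-c2cccnc2)c2ccccc2c1=O` gives 99%, compound 2 `O=c1c2ccccc2c(-c2cccnc2)nn1CC1CCCCC1` gives 98%, and compound 3 `O=c1c2ccccc2c(-c2cccnc2)nn1CCSc1ncccn1` gives 86%. Compound 3 thus stands lowest of the three numbers, with compound 2 nearest and compound 1 furthest, both gaps beyond the scatter. The steps connecting them were a number 1 percentage points lower from compound 1 to compound 2 (within the scatter), a number 13 percentage points lower from compound 1 to compound 3 (beyond the scatter) and a number 12 percentage points lower from compound 2 to compound 3 (beyond the scatter).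

Compound 4 `NCCn1nc(-c2cccnc2)c2ccccc2c1=O` has not yet been measured. It differs from compound 3 in one place: amino in place of (pyrimidin-2-yl)sulfanyl on a saturated chain carbon, two bonds along the chain from an aromatic nitrogen. For the measured compounds named here, no measured step exchanges the (pyrimidin-2-yl)sulfanyl for an amino, so the closest guides are a number 13 percentage points lower from compound 1 to compound 3 (beyond the scatter) and a number 12 percentage points lower from compound 2 to compound 3 (beyond the scatter), in which the arrival of that group brought a modest loss. Its departure now comes together with an amino rather than a return to heptyl or cyclohexyl, so a step of that earlier size in either direction remains possible, and the expectation carries wide uncertainty. Compound 4 is therefore expected to give about 75%, in a range from 50% to 92%. This estimate corresponds to an expected a number 11 percentage points lower from compound 3 to compound 4 (beyond the scatter).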

Compound 4, a percentage reported as inhibition, at one concentration (the size of the read-out at that concentration, not a potency): 29%
Compound 4: middle estimate off by 46 percentage points, on the high side; measured number below the stated range.
By their numbers in this assay, from the lowest: compound 4; then compound 3; then compounds 2 and 1 (each within the scatter of the next).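

The change of compound 3 into compound 4 shows that this position does not accept every group in this assay: the exchange of (pyrimidin-2-yl)sulfanyl for amino gave a number 57 percentage points lower from compound 3 to compound 4 (beyond the scatter), a large step where the earlier changes had been no more than modest. The losses measured against the two compounds with all-carbon groups are also large, with a number 69 percentage points lower from compound 2 to compound 4 (beyond the scatter) and a number 70 percentage points lower from compound 1 to compound 4 (beyond the scatter), so the heptyl and cyclohexyl compounds, which stood within the scatter of each other, give no sign that the amino compound would fall so far. The compounds therefore show that a group on this chain can decide most of the inhibition seen at the tested concentration, although nothing reported here accounts for the size of this loss.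

On these data alone, it remains open whether the loss belongs to the amino group itself or to the removal of the larger group and the shorter substituent that results. A hydroxyl or a dimethylamino in the same place, or an amine at the end of a longer chain, would separate these two readings.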